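This account rests on a few compounds, and the source may have more. Where it says the series, first, only, none or still open, it means among the compounds named here.

Compound 1 `O=C(NO)c1cc2ccn(Cc3ccc(F)cc3F)c2cn1`: > 320000 nM (a limit)
Compound 2 `CN(O)C(=O)c1cc2ccn(Cc3ccc(F)cc3F)c2cn1`: 135000 nM

Of the compounds shown here, two on a shared core have been measured in an ADME assay on CEM-SS cells (Homo sapiens) for cytotoxicity, read by XTT assay; a lower number here means that less compound is tolerated, a higher number that more compound is tolerated. Compound 1 reaches only a limit of the assay, > 320000 nM. For the measured compounds named here, compound 2 gives 135000 nM, the only actual number so far.

The next compound is compound 3 `CONC(=O)c1cc2ccn(Cc3ccc(F)cc3F)c2cn1`, which has the same atoms as compound 2, joined differently. The change is methoxyamino in place of hydroxy(methyl)amino on a carbonyl carbon. Going by the values given here, only one measured step bears on it. Methyl in place of hydrogen on an amide-type nitrogen gave an at least 2.3-fold lower number from compound 1 to compound 2 (0.37 log units; beyond the scatter). Compound 3 no longer carries that methyl on the nitrogen, but it still holds a methyl in the methoxyamino group, so only part of that step is expected to be undone. In this assay, no step beyond the scatter is therefore expected, although the measured step leaves room towards a higher number. The expected change is a 1.3-fold higher number from compound 2 to compound 3 (0.12 log units; within the scatter). Compound 3 is estimated at 180000 nM, with an expected range of 80000 nM to 400000 nM.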

Compound 3, half-maximal cytotoxic concentration: > 320000 nM
Compound 3: only a limit was reported; the forecaster's own chance of this, stated with the estimate: 35%; at least 1.7-fold (0.24 log units) between middle value and limit.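

In this assay, methoxyamino in place of hydroxy(methyl)amino on a carbonyl carbon gives an at least 2.3-fold higher number from compound 2 to compound 3 (0.37 log units; beyond the scatter). The earlier compounds shown here showed only that adding a methyl on the nitrogen lowered the number; this pair, with the same atoms joined differently, shows that the methyl's place within the group matters and not merely its presence. Among the three compounds, only compound 2, with the methyl on the nitrogen, gives an actual number, while the step from compound 1 to compound 3 cannot be read, as both are reported only as a limit, so any effect of a methyl in place of hydrogen on the oxygen stays hidden: the limit of > 320000 nM in this assay, at which 2 of the 3 values shown sit.

Going by these compounds, how far compound 1 and compound 3 lie beyond that limit remains open, and so does the full size of the step to compound 3. Also open, on these data alone, is whether the lower number follows a methyl on the nitrogen in other settings, such as a dimethylamino group on the same carbonyl carbon, or whether a longer chain such as ethoxyamino would stay at the limit.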